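Chloro added to the benzoate ester of compound 2

A few compounds are considered here, and "the series" means these few. Any claim that something is new, unique, unknown or untested is made for them only; others in the source may bear on it.

Compound 1 `C=C1CC[C@@H]2CCC3=C(C2(C)C)[C@@](O)(C/C(C)=C/[C@@H](O)C1)OC3=O`: in a functional assay on Daoy cells (Homo sapiens) for cytotoxicity, read by MTT assay (on this read-out higher numbers stand for weaker inhibition and lower numbers for stronger inhibition), compound 1 gives > 20 ug/mL
Compound 2 `C=C1CC[C@@H]2CC[C@H](OC(=O)C/C(C)=C/[C@@H](OC(=O)c3ccccc3)C1)C(=O)C2(C)C`: in this assay compound 2 gives > 20 ug/mL

Both values are limits of the assay, not numbers. For compound 1 the value > 20 ug/mL is such a limit. For compound 2 the value > 20 ug/mL is also a limit, so compound 2 sits at the limit of > 20 ug/mL in this assay, at which 2 of the 2 values shown sit, together with every value shown. Compound 3 `C=C1CC[C@@H]2CC[C@H](OC(=O)C/C(C)=C/[C@@H](OC(=O)c3ccc(Cl)cc3)C1)C(=O)C2(C)C` differs from compound 2 by chloro in place of hydrogen on an aromatic carbon. Within the data shown here, no step between measured compounds is available, so the expected step that the limit leaves unreadable from compound 2 to compound 3 is none beyond the scatter. Compound 3 is therefore expected to give about 25 ug/mL, between 10 ug/mL and 60 ug/mL, most likely again reported as a limit.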

Compound 3, half-maximal inhibitory concentration: > 20 ug/mL
Compound 3: no number, only a limit; the forecaster's own chance of this, stated with the estimate: 75%; the middle value lies beyond the limit too.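

No step can be read from compound 2 to compound 3, because both values are limits of the assay rather than numbers: the limit of > 20 ug/mL in this assay, at which 3 of the 3 values shown sit.

The compounds shown leave open whether 4-chlorophenyl in place of phenyl changes cytotoxicity at all.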